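Biphenyl in place of naphthyl on a thiourea nitrogen

A few compounds are considered here, and "the series" means these few. Any claim that something is new, unique, unknown or untested is made for them only; others in the source may bear on it.

Three compounds sharing one core were measured in a functional assay on MKN-74 cells (Homo sapiens) for antiproliferative activity, with a stated time of 24 h; a higher number here means a weaker inhibitor, a lower number a stronger inhibitor. Compound 1 `NC(=O)c1c(NC(=O)c2ccccc2Cl)sc2c1CCN(Cc1cc(Cl)cc(Cl)c1)C2` gives 23700 nM, compound 2 `NC(=O)c1c(NC(=O)c2cccc([N+](=O)[O-])c2)sc2c1CCN(Cc1ccc(Cl)cc1Cl)C2` gives 16500 nM, and compound 3 `NC(=O)c1c(NC(=O)c2ccccc2Cl)sc2c1CCN(C(=S)Nc1cccc3ccccc13)C2` gives 20700 nM. All three numbers lie within the usual scatter of one another, so compound 3 is not set apart from compound 1 or compound 2. Compound 4 `NC(=O)c1c(NC(=O)c2ccccc2Cl)sc2c1CCN(C(=S)Nc1ccccc1-c1ccccc1)C2` differs from compound 3 in one place: 2-phenylphenyl in place of naphthalen-1-yl on an amide-type nitrogen. Within the data shown here, no measured pair shows what such a swap does, and the three numbers at hand give no hint that a change there moves the read-out. Compound 4 is therefore expected to stay close to compound 3. The expected step of a 1.0-fold lower number from compound 3 to compound 4 (0.01 log units; within the scatter) is one of no size beyond the scatter. The estimated half-maximal inhibitory concentration for compound 4 is 20000 nM, within 8000 nM to 50000 nM.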

Compound 4, half-maximal inhibitory concentration: 25800 nM
Compound 4: the middle estimate sits 1.3-fold (0.11 log units) below what was measured; low and high end bracket the measured number.
By their numbers in this assay, from the lowest: compounds 2, 3, 1 and 4 (each within the scatter of the next).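

Replacing naphthalen-1-yl with 2-phenylphenyl on this amide-type nitrogen gives a 1.2-fold higher number from compound 3 to compound 4 (0.10 log units; within the scatter) in this assay and the two groups, each with two six-membered aromatic rings of carbon only, cannot be told apart here. Going to the group with more heavy atoms at this position leaves the read-out within the scatter. Nothing available explains this result. On these data alone, whether a different kind of group on this nitrogen, such as a cyclohexyl ring, a carboxylic acid or an amine, would shift the number stays open. So does whether any change at this position can move it beyond the scatter.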